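The compounds below may be only part of what the source reports. "The series", "measured", "known", "first", "only" and "open" are said of these compounds alone.

Values measured in a functional assay on MCF7 cells (Homo sapiens) for cytotoxicity, read by MTT assay, with a stated time of 24 h (a higher number here means a weaker inhibitor, a lower number a stronger inhibitor), are:

- Compound 1 `Cc1ncc([N+](=O)[O-])n1CCOc1ccccc1`: 106 ug/mL
- Compound 2 `Cc1ncc([N+](=O)[O-])n1CCOc1ccccc1Cl`: 378 ug/mL
- Compound 3 `Cc1ncc([N+](=O)[O-])n1CCOc1ccccc1[N+](=O)[O-]`: 583 ug/mL

Compound 1 has the lowest number of the three, which makes it the strongest inhibitor here. Compound 4 `Cc1ncc([N+](=O)[O-])n1CCOc1ccc(C#N)cc1` is compound 1 with cyano in place of hydrogen on an aromatic carbon. Two measured steps also replace hydrogen on an aromatic carbon, namely a 3.6-fold higher number from compound 1 to compound 2 (0.55 log units; beyond the scatter) and a 5.5-fold higher number from compound 1 to compound 3 (0.74 log units; beyond the scatter). Both are modest, beyond the scatter and point the same way. Neither involves cyano, so they offer only a loose guide. A modest rise is expected, and the estimate is a 2.8-fold higher number from compound 1 to compound 4 (0.45 log units; beyond the scatter) in this assay. Compound 4 is estimated at 300 ug/mL (expected range 120 ug/mL to 700 ug/mL).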

Compound 4, half-maximal inhibitory concentration: 83.2 ug/mL
Estimate against measurement, compound 4: 3.6-fold (0.56 log units) above, outside the stated range (below it).
By their numbers in this assay, from the lowest: compounds 4 and 1 (each within the scatter of the next); then compounds 2 and 3 (each within the scatter of the next).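

In this assay, cyano on an aromatic carbon para to a large group gives a 1.3-fold lower number from compound 1 to compound 4 (0.11 log units; within the scatter) and so cannot be told apart from hydrogen at that place. The chloro and nitro replacements each gave a step beyond the scatter, so putting a group on this aromatic ring does not always raise the number. No measured property bears on this contrast.

Going by these compounds, whether the result belongs to cyano itself or to its place on the ring stays open, as cyano appears at only this one place. An amine or a carboxylic acid at the same place could also give a different number.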